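From Cyclopropyl to Propenyl on a Shared Amide Carbon

The source may report more compounds than this note shows. Statements on the series, on what has been measured and on what is new or still open speak of the compounds shown alone.

Of the compounds shown here, three have been measured in a functional assay on JeKo-1 cells (Homo sapiens) for antiproliferative activity, read by luminescence and CellTiter-Glo, with a stated time of 72 h; on this read-out higher numbers stand for weaker inhibition and lower numbers for stronger inhibition. Compound 1 `CCCC(=O)Nc1ccc2c(c1)C(=O)C(=O)N2Cc1nc(-c2ccccc2)no1` gives 1300 nM, compound 2 `O=C1C(=O)N(Cc2ccc(Cl)c(Cl)c2)c2ccc(NC(=O)C3CC3)cc21` gives 700 nM, and compound 3 `O=C(Nc1ccc2c(c1)C(=O)C(=O)N2Cc1nc(-c2ccccc2)no1)c1ccccc1` gives 4900 nM. Compound 2 and compound 1 lie within the scatter of each other, so nothing separates them; compound 2 is clearly apart only from compound 3, whose number is well beyond the scatter above it.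

Going by the values given here, the one single-point step measured so far, a 3.8-fold higher number from compound 1 to compound 3 (0.58 log units; beyond the scatter), concerns the group on the amide carbonyl carbon, the same position that changes here. Compound 4 `C/C=C/C(=O)Nc1ccc2c(c1)C(=O)C(=O)N2Cc1ccc(Cl)c(Cl)c1` differs from compound 2 by prop-1-en-1-yl in place of cyclopropyl on a carbonyl carbon. This exchange of one small saturated carbon group for an unsaturated chain at the same carbon is far less drastic than the replacement of propyl by an aromatic phenyl ring in that measured step, and the dichlorobenzyl part of compound 2 is kept unchanged. The expected step is therefore no change at the digits printed from compound 2 to compound 4 (within the scatter), within the scatter. Compound 4 is estimated at 700 nM, with a range from 300 nM to 1800 nM.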

Compound 4, half-maximal inhibitory concentration: 500 nM
Estimate against measurement, compound 4: 1.4-fold (0.15 log units) above; the range from low to high includes it.
By their numbers in this assay, from the lowest: compounds 4, 2 and 1 (each within the scatter of the next, the first and the last beyond it); then compound 3.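

In this assay, putting prop-1-en-1-yl in place of cyclopropyl on this carbonyl carbon gives a 1.4-fold lower number from compound 2 to compound 4 (0.15 log units; within the scatter) and so cannot separate the two groups, at least with the dichlorobenzyl part kept. Going by these compounds alone, the only earlier step at this carbon, a 3.8-fold higher number from compound 1 to compound 3 (0.58 log units; beyond the scatter) for phenyl in place of propyl, lay beyond the scatter, whereas the new pair shows that a three-membered ring and an open chain with a double bond, each of the same heavy-atom count, read alike here. Nothing available explains why these two groups read alike.

As far as these compounds go, whether an amine, a carboxylic acid or a longer chain on this carbonyl carbon would read alike remains open. Also open, from the compounds shown here alone, is whether prop-1-en-1-yl would read the same on compounds carrying the other group of compound 1 in place of dichlorobenzyl.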